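Swapping 3,4,5-Trimethoxyphenyl for 3-Bromo-4-hydroxyphenyl

This account rests on a few compounds, and the source may have more. Where it says the series, first, only, none or still open, it means among the compounds named here.

In a functional assay on MCF7 cells (Homo sapiens) for cytotoxicity, read by MTT assay, with a stated time of 72 h (a lower number here means a stronger inhibitor, a higher number a weaker inhibitor), compound 1 (`O=C(N/N=C/c1cccc(Cl)c1Cl)Nc1cc2c(Nc3ccc(F)c(Cl)c3)ncnc2cc1O[C@H]1CCOC1`) is reported as "not active" (no number reported) and carries no number. Going by the values given here, compound 2 (`COc1cc(/C=N/NC(=O)Nc2cc3c(Nc4ccc(F)c(Cl)c4)ncnc3cc2O[C@H]2CCOC2)cc(OC)c1OC`) gives 26500 nM in this assay and holds the only number available, so it cannot be ranked against another value. Compound 3 (`O=C(N/N=C/c1ccc(O)c(Br)c1)Nc1cc2c(Nc3ccc(F)c(Cl)c3)ncnc2cc1O[C@H]1CCOC1`) has not yet been measured. It carries 3-bromo-4-hydroxyphenyl in place of 3,4,5-trimethoxyphenyl on a carbon with a double bond to nitrogen. Among the compounds with values here, no measured step between two compounds differing in one place is available to guide this change. The reference is therefore compound 2 at 26500 nM and no shift beyond the scatter is expected in either direction. The estimated step of a 1.3-fold lower number from compound 2 to compound 3 (0.12 log units; within the scatter) is expected to stay within the scatter. In this assay compound 3 is expected at 20000 nM with a likely range of 7000 nM to 60000 nM for the coming measurement.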

Compound 3, half-maximal inhibitory concentration: 2690 nM
Compound 3: the middle estimate sits 7.4-fold (0.87 log units) above what was measured; the whole stated range lies above it.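

The aryl group on a carbon with a double bond to nitrogen now proves able to shift the read-out in this assay: replacing 3,4,5-trimethoxyphenyl with 3-bromo-4-hydroxyphenyl gives a 9.9-fold lower number from compound 2 to compound 3 (0.99 log units; beyond the scatter) and takes the step beyond the scatter. Going by these compounds alone, earlier, this position offered only a single number, and no effect of changing the group could be read. No measured finding accounts for the step, so it stands as an observation about the whole exchange.

The exchange alters several features at once, and the compounds shown leave open whether the bromine, the hydroxyl or the loss of the methoxy groups carries the step. Nor do they show how 3-bromophenyl, 4-hydroxyphenyl or a ring bearing an amine or a carboxylic acid would behave here.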